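Compound 3: 2-chlorophenyl in place of 4-fluorophenyl

The source may report more compounds than this note shows. Statements on the series, on what has been measured and on what is new or still open speak of the compounds shown alone.

Compound 1 `O=C1Nc2ccc(F)cc2/C1=C/c1ccc(-c2cn(-c3ccccc3F)nn2)cc1` gives 14400 nM as a measured number
Compound 2 `O=C1Nc2ccc(F)cc2/C1=C/c1ccc(-c2cn(-c3ccc(F)cc3)nn2)cc1` gives > 20000 nM as a limit

In an ADME assay on HUVEC cells (Homo sapiens) for inhibition, read by CCK-8 assay, with a stated time of 24 h, in the presence of a further agent that is not named here (on this read-out lower numbers stand for stronger inhibition and higher numbers for weaker inhibition), compound 1 gives 14400 nM as a measured number. Compound 2 sits at the limit of > 20000 nM in this assay, at which 1 of the 2 values shown sits, and has no number of its own. Compound 3 `O=C1Nc2ccc(F)cc2/C1=C/c1ccc(-c2cn(-c3ccccc3Cl)nn2)cc1` differs from compound 2 by 2-chlorophenyl in place of 4-fluorophenyl on an aromatic nitrogen with 2-chlorophenyl in place of 4-fluorophenyl on an aromatic nitrogen. Within the data shown here, one measured step bears on this change, namely an at least 1.3-fold higher number from compound 1 to compound 2 (0.14 log units; that floor lies within the scatter) with 4-fluorophenyl in place of 2-fluorophenyl on an aromatic nitrogen. The new change runs the other way, from a 4-fluorophenyl to a 2-substituted phenyl by name, so that step is read backward with caution. The 2-chlorophenyl of compound 3 is closest by name to the 2-fluorophenyl of compound 1 at 14400 nM and that value anchors the expectation. A modest move toward lower numbers is expected, though it may not clear the scatter. The expected change is an at least 1.5-fold lower number from compound 2 to compound 3 (0.18 log units; that floor lies within the scatter) on this estimate. For compound 3 the estimated value in this assay is 13000 nM with an expected range from 6500 nM to 20000 nM as the likely span.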

Compound 3, half-maximal inhibitory concentration: 18200 nM
Compound 3: the middle estimate sits 1.4-fold (0.15 log units) below what was measured, and the stated range covers the measured number.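

Setting 2-chlorophenyl on the aromatic nitrogen of the five-membered ring in this assay gives an at least 1.0-fold lower number from compound 2 to compound 3 (0.04 log units; that floor lies within the scatter), so this exchange for 4-fluorophenyl yields a measured number but no shift that can be told from the scatter. Between the two groups that differ only in their halogen, the change gives a 1.3-fold higher number from compound 1 to compound 3 (0.10 log units; within the scatter), so fluoro and chloro on this aromatic carbon cannot be told apart in this read-out. The comparison with 4-fluorophenyl remains bounded on one side only, as compound 2 has a limit and not a number: the limit of > 20000 nM in this assay, at which 1 of the 3 values shown sits.

All the compounds shown carry a halogen-bearing phenyl on this nitrogen, and their numbers offer no step beyond the scatter at this place. On these data alone, it stays open whether a phenyl bearing an amine or a carboxylic acid, or a longer chain in place of the phenyl, would move the number beyond the scatter, and what 4-chlorophenyl would give beside the 2-chlorophenyl of compound 3.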